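The source may hold more compounds than are shown below. What is called first, only, known or untested is meant among the compounds shown, and "the series" means these compounds.

Measured in an assay on isolated protein with retinoic acid receptor alpha (Homo sapiens) as the target; a higher number here means a larger maximal response, a lower number a smaller maximal response:
Compound 1 `CC1(C)CCC(C)(C)c2c(F)cc(C(=O)c3ccc4cc(C(=O)O)ccc4c3)cc21` gives 63%.
Compound 2 `COc1c(C(=O)c2ccc3c(c2)C(C)(C)CCC3(C)C)ccc2cc(C(=O)O)ccc12` gives 0%.

Compound 2 stands lowest of the two numbers in this assay; its nearest neighbour is compound 1, whose value lies higher by a gap that is beyond the scatter. Going by the values given here, no pair differing in one place has been measured, so nothing is known about how single changes at the methoxy or at the fluorine move the readout.

Compound 3 `CC1(C)CCC(C)(C)c2cc(C(=O)c3ccc4cc(C(=O)O)ccc4c3O)ccc21` is the next member. Against compound 2 the change is hydrogen in place of methyl on an oxygen on an aromatic ring, that is methoxy to hydroxy. Among the compounds with values here, what this does in this assay cannot be read from the two measured values; the only anchor is that compound 2 sits at the floor in this assay, so the step can only go up or stay flat. An upward step of moderate size is expected, with wide uncertainty. Expected is a step of a number 25 percentage points higher from compound 2 to compound 3 (beyond the scatter). Compound 3 is estimated at 25%, in the range 0% to 65%.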

Compound 3, largest response reached (reported as maximum), in percent of the reference or control that the assay uses: 0%
For compound 3 the middle estimate is 25 percentage points above the measured one, and the stated range covers the measured number.
By their numbers in this assay, from the lowest: compounds 2 and 3 (each within the scatter of the next); then compound 1.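

In this assay, methoxy to hydroxy on the aromatic ring brings no change at the digits printed from compound 2 to compound 3 (within the scatter). Removing the methyl from this oxygen is therefore not enough to give a measurable maximal response, and with both compounds at the bottom of the scale, any underlying difference between the two groups would not show in this read-out. No available data explain this result.

As far as these compounds go, it remains open whether another group in this place, such as an amine, ethoxy or plain hydrogen on the aromatic ring, would give a response above that of compound 2. No pair shown isolates the fluorine of compound 1, so its contribution to the value of that compound also remains open.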